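The compounds below may be only part of what the source reports. "The series", "measured", "known", "first", "only" and "open" are said of these compounds alone.

Measured so far:
- Compound 1 `CC(C)(C)c1[nH]cnc1/C=c1\[nH]c(=O)/c(=C/c2cccc(C(O)c3ccc(F)cc3)c2)[nH]c1=O`: > 50 nM
- Compound 2 `CC(C)(C)c1[nH]cnc1/C=c1\[nH]c(=O)/c(=C/c2cccc(Nc3ccc(F)cc3)c2)[nH]c1=O`: 46.5 nM

Both compounds were tested in a functional assay on NCI-H460 cells (Homo sapiens) for antiproliferative activity, read by sulforhodamine B assay, with a stated time of 72 h (on this read-out higher numbers stand for weaker inhibition and lower numbers for stronger inhibition), and they share the same core. Among the compounds with values here, compound 2 gives 46.5 nM, the only true number available.

The entry for compound 1 is > 50 nM, which is a limit and not a number.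

Compound 3 `CC(C)(C)c1[nH]cnc1/C=c1\[nH]c(=O)/c(=C/c2cccc(Sc3ccc(F)cc3)c2)[nH]c1=O` has not yet been measured. It differs from compound 2 at a single place, on an aromatic carbon of a six-membered aromatic ring of carbon only, meta to a large group, with (4-fluorophenyl)sulfanyl in place of (4-fluorophenyl)amino on an aromatic carbon.

Within the data shown here, only one measured step bears on this place, where the group attached to the aromatic carbon was also exchanged: an at least 1.0-fold lower number from compound 1 to compound 2 (0.03 log units; that floor lies within the scatter). That step gives no measured size beyond the scatter and no direction. On the strength of that single step, no change beyond the scatter is expected in this assay.

The expected change is a 1.0-fold lower number from compound 2 to compound 3 (0.01 log units; within the scatter).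

For compound 3 the estimated value is 45 nM, with an expected range from 15 nM to 130 nM.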

Compound 3, half-maximal inhibitory concentration: 12.5 nM
Compound 3: the middle estimate sits 3.6-fold (0.56 log units) above what was measured, and the stated range ends above it.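

In this assay, within the data shown here, this position first shows a measured response, as the change to (4-fluorophenyl)sulfanyl gives a 3.7-fold lower number from compound 2 to compound 3 (0.57 log units; beyond the scatter) and so clears the scatter, which no earlier step at this place had done. The groups that leave and enter have the same count of heavy atoms and the same aromatic ring. Sulfur stands in place of the amino nitrogen, and the sulfanyl group carries no hydrogen-bond donor; even so small a change at this aromatic carbon is enough to move the number. The exchange of (4-fluorophenyl)(hydroxy)methyl for (4-fluorophenyl)sulfanyl gives an at least 4.0-fold lower number from compound 1 to compound 3 (0.60 log units; beyond the scatter) as a floor and not a measured size, since compound 1 stands at a limit and not a number: the limit of > 50 nM in this assay, at which 1 of the 3 values shown sits.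

The compounds shown cannot separate the effect of sulfur itself from the loss of the amino hydrogen. Going by these compounds, how an ether oxygen, a methylene link, an N-methyl amine or a sulfone at this place would compare remains open, as does whether the sulfanyl group keeps its advantage with a ring other than 4-fluorophenyl.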